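Swapping the aromatic group on compound 3

A few compounds are considered here, and "the series" means these few. Any claim that something is new, unique, unknown or untested is made for them only; others in the source may bear on it.

- compound 1 `Cc1ccc(CS/C(=C/c2ccc(O)cc2)C(=O)c2ccc(Cl)cc2)cc1` gives 10000 nM
- compound 2 `CSc1ccc(/C=C(/SCc2ccc(C)cc2)C(=O)c2ccc(Cl)cc2)cc1` gives 25000 nM
- compound 3 `Cc1ccc(CS/C(=C/c2ccc(Br)cc2)C(=O)c2ccc(Cl)cc2)cc1` gives 10000 nM

These numbers come from a functional assay on DU-145 cells (Homo sapiens) for inhibition, read by trypan blue exclusion, with a stated time of 96 h (on this read-out lower numbers stand for stronger inhibition of growth and higher numbers for weaker inhibition of growth), and place compound 3 level with compound 1, together the lowest of the three. Compound 4 `Cc1ccc(CS/C(=C/c2ccc(C)s2)C(=O)c2ccc(Cl)cc2)cc1` differs from compound 3 by one swap, (5-methylthiophen-2-yl in place of 4-bromophenyl on a double-bonded chain carbon bound to a double-bonded chain carbon), with 5-methylthiophen-2-yl in place of 4-bromophenyl. The measured steps only exchange a group on an aromatic carbon, such as no change at the digits printed from compound 1 to compound 3 (within the scatter) for bromo in place of hydroxy and a 2.5-fold lower number from compound 2 to compound 3 (0.40 log units; beyond the scatter) for bromo in place of methylsulfanyl. None replaces a whole aromatic group, so they are a weak guide. Those steps are small, so no step beyond the scatter is expected in this assay here. The expected step is a 1.2-fold higher number from compound 3 to compound 4 (0.08 log units; within the scatter) and it remains an estimate. For compound 4 the estimated value is 12000 nM, with an expected range from 5000 nM to 30000 nM.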

Compound 4, concentration for 50% growth inhibition: 50000 nM
Beside the measured number, compound 4's estimate is 4.2-fold (0.62 log units) below it; the whole stated range lies below it.
By their numbers in this assay, from the lowest: compounds 1 and 3 (each within the scatter of the next); then compounds 2 and 4 (each within the scatter of the next).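

Exchanging the whole aromatic group on this double-bonded chain carbon, rather than only a group on the ring, gives the widest steps seen so far in this assay: a 5.0-fold higher number from compound 3 to compound 4 (0.70 log units; beyond the scatter) and a 5.0-fold higher number from compound 1 to compound 4 (0.70 log units; beyond the scatter). Against the 4-(methylsulfanyl)phenyl group, however, the change gives a 2.0-fold higher number from compound 2 to compound 4 (0.30 log units; within the scatter), so not every exchange of this ring separates the compounds. Nothing measured here explains these steps.

From the compounds shown here alone, it remains open whether the five-membered ring or its methyl group drives the change. An unsubstituted thiophen-2-yl group or a 4-aminophenyl group at this position could help separate these possibilities.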